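Swapping hydroxymethyl for phenoxy in compound 2

The source may report more compounds than this note shows. Statements on the series, on what has been measured and on what is new or still open speak of the compounds shown alone.

Three compounds have been measured so far in a physicochemical assay for lipophilicity, using the shake flask method, measured as octanol-water partition (a higher number here means a more lipophilic compound, a lower number a more polar compound), as follows:

- Compound 1 `O=C(NNC1CCC(c2ccccc2)CC1)c1ccncc1` gives 2.83
- Compound 2 `O=C(N/N=C/c1ccc(CO)cc1)c1ccncc1` gives 0.731
- Compound 3 `CCCCCC(C)C(=O)NNC(=O)c1ccncc1` gives 2.09

Compound 2 stands lowest of the three, and compound 3 and compound 1 both lie above it by more than the usual scatter. Compound 4 `O=C(N/N=C/c1ccc(Oc2ccccc2)cc1)c1ccncc1` has not yet been measured. It carries phenoxy in place of hydroxymethyl on an aromatic carbon and otherwise matches compound 2. For the measured compounds named here, no two measured compounds differ in only one place, so no measured step directly guides the size of this change. The nearest hint is that compound 1, the largest molecule measured, gives 2.83 in this assay and stands highest of the three. On that limited evidence, a large upward step of a number 2.57 log units higher from compound 2 to compound 4 (beyond the scatter) is expected, well beyond the scatter. The estimate for compound 4 is 3.3 at its middle, with 2.6 to 4 as the expected range.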

Compound 4, partition coefficient: 3.7
Compound 4: the middle estimate sits 0.40 log units below what was measured; the range from low to high includes it.
By their numbers in this assay, from the lowest: compound 2; then compound 3; then compound 1; then compound 4.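

In this assay, replacing hydroxymethyl with phenoxy on an aromatic carbon, para to a large group, gives a number 2.97 log units higher from compound 2 to compound 4 (beyond the scatter), the first step shown in which only one place changes. The earlier compounds shown here differ from one another in more than one place, so they could not show that a single exchange at this position can move the number by such a large amount. This exchange adds a six-membered aromatic ring of carbon only and removes a hydrogen-bond donor, and nothing measured here explains the size of the step or separates those two differences.

Going by these compounds, it remains open how the number would respond to a methoxy group, a phenyl group or an amine on the same aromatic carbon, and therefore which part of phenoxy goes with the step. On these data alone, whether the same exchange would give a similar step on a different core also remains open.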